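Cyano in Place of Ethynyl on Compound 1

The source may report more compounds than this note shows. Statements on the series, on what has been measured and on what is new or still open speak of the compounds shown alone.

Compound 1 `C#Cc1cc(-c2nc3ccccc3s2)ccc1N` gives 15 nM in a functional assay on MDA-MB-468 cells (Homo sapiens) for inhibition, with a stated time of 72 h (a lower number here means a stronger inhibitor of growth, a higher number a weaker inhibitor of growth), the lowest of the three numbers measured. Compound 2 `C#Cc1cc(-c2nc3c(F)cccc3s2)ccc1N` gives 30 nM, and a 2.0-fold higher number from compound 1 to compound 2 (0.30 log units; within the scatter). Compound 3 `C[Si](C)(C)C#Cc1cc(-c2nc3c(F)cccc3s2)ccc1N` gives 230 nM, and a 7.7-fold higher number from compound 2 to compound 3 (0.88 log units; beyond the scatter). Compound 4 `N#Cc1cc(-c2nc3ccccc3s2)ccc1N` differs from compound 1 by cyano in place of ethynyl on an aromatic carbon. Among the compounds with values here, no measured step exchanges one group for another at that carbon; the only step touching the triple-bonded carbon, a 7.7-fold higher number from compound 2 to compound 3 (0.88 log units; beyond the scatter), places a group of 4 heavy atoms there, while a 2.0-fold higher number from compound 1 to compound 2 (0.30 log units; within the scatter) stays within the scatter. The cyano, like the ethynyl, carries one triple bond outside aromatic rings, so the step of a 2.0-fold higher number from compound 1 to compound 4 (0.30 log units; within the scatter) is expected to be small, at most a slight rise. Compound 4 is therefore estimated at 30 nM, ranging from 8 nM to 120 nM.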

Compound 4, concentration for 50% growth inhibition: 340 nM
Compound 4: the middle estimate sits 11-fold (1.05 log units) below what was measured, outside the stated range (above it).
By their numbers in this assay, from the lowest: compounds 1 and 2 (each within the scatter of the next); then compounds 3 and 4 (each within the scatter of the next).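

At this aromatic carbon, ortho to an amino group, ethynyl and cyano are not interchangeable: in this assay the exchange gives a 23-fold higher number from compound 1 to compound 4 (1.36 log units; beyond the scatter), although the two groups match in heavy-atom count and each has one triple bond outside aromatic rings. Within the data shown here, the earlier compounds all keep ethynyl or a substituted ethynyl here, so only this step replaces the group itself. Nothing measured here accounts for the step.

As far as these compounds go, it remains open how a chloro or a methyl at this carbon would compare with ethynyl, and whether the same exchange would give a step of similar size with the fluoro of compound 2 present.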